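A Fluorine Added Where Nothing Is Yet Measurable

The compounds below may be only part of what the source reports. "The series", "measured", "known", "first", "only" and "open" are said of these compounds alone.

Compound 1 `Nc1nn2c(O)cc(-c3cc([N+](=O)[O-])c(Cl)cc3Cl)nc2c1[N+](=O)[O-]` and compound 2 `Nc1nn2c(O)cc(-c3ccccc3)nc2c1[N+](=O)[O-]` share one core and differ only in the aryl group attached to it. In a functional assay on L929 cells (Mus musculus) for inhibition (a lower number here means a stronger inhibitor of growth, a higher number a weaker inhibitor of growth), compound 1 reaches only > 50 ug/mL, which is a limit of the assay and not a number. In this assay compound 2 likewise gives only > 50 ug/mL, again a limit rather than a measured number. Compound 2 therefore stands at the limit of > 50 ug/mL in this assay, at which 2 of the 2 values shown sit, and there is no number that ranks it against any other compound. Compound 3 `Nc1nn2c(O)cc(-c3ccccc3F)nc2c1[N+](=O)[O-]` has not been measured; it differs from compound 2 by fluoro in place of hydrogen on an aromatic carbon. For the measured compounds named here, no step between measured compounds is available, so the size of this step cannot be read from the data. Compound 3 is expected to remain at the same limit, with the step that the limit leaves unreadable from compound 2 to compound 3 not exceeding the scatter should a number appear at all. The estimate for compound 3 in this assay is 60 ug/mL, ranging from 20 ug/mL to 200 ug/mL.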

Compound 3, concentration for 50% growth inhibition: > 50 ug/mL
Compound 3 ended at the assay's limit; the forecaster's own chance of this, stated with the estimate: 85%; the middle value does not contradict the limit.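

For the compounds shown here, compound 2 and compound 3 both stand at a limit of the assay and not at a number, so no step between them can be read. The compounds shown leave open whether phenyl to 2-fluorophenyl changes growth inhibition at all, and what aryl group on the shared core would bring a measurable value.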